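The compounds below may be only part of what the source reports. "The series", "measured", "known", "first", "only" and "open" are said of these compounds alone.

Compound 1 `COc1ccc(-c2cnc(N)nc2C2CC2)cc1`: > 100000 nM (a limit)
Compound 2 `Nc1ncc(-c2ccncc2-c2ccoc2)c(C2CC2)n1`: 28000 nM
Compound 3 `CC(C)c1nc(N)ncc1-c1ccncc1`: > 100000 nM (a limit)

All three were tested in a functional assay on CUTLL1 cells (Homo sapiens) for inhibition, read by resazurin assay, with a stated time of 48 h, in the presence of a further agent that is not named here; on this read-out lower numbers stand for an effect already at smaller amounts and higher numbers for an effect only at larger amounts of compound. In this assay compound 3 gives no number, only the limit > 100000 nM. Among the compounds with values here, the series so far is marked by the limit of > 100000 nM in this assay, at which 2 of the 3 values shown sit. Within the data shown here, compound 2 is the only one with a number, 28000 nM.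

Next comes compound 4 `Nc1ncc(-c2ccncc2)cn1`, not yet measured. It differs from compound 3 in one place: hydrogen in place of isopropyl on an aromatic carbon. Among the measured compounds shown here, no measured pair shows this change, so its size has to be judged without a direct precedent. The starting point is weak ground as well, since compound 3 stands at a limit, > 100000 nM. The expected step, a number no higher from compound 3 to compound 4 (the limit leaves the size open), is estimated to stay within the usual scatter, with no clear change in either direction. Compound 4 is expected at about 100000 nM, with an estimated range of 40000 nM to 250000 nM, and the read-out may well again be only a limit.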

Compound 4, half-maximal effective concentration: > 100000 nM
Compound 4: no number, only a limit (the forecaster's own chance of this, stated with the estimate: 80%); the middle value sits exactly at the limit.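

Compound 3 and compound 4 both give only a limit in this assay, so the step between them cannot be read: the limit of > 100000 nM in this assay, at which 3 of the 4 values shown sit. The compounds shown leave open what hydrogen in place of isopropyl on an aromatic carbon does to a numerical value in this assay.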